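Removing One Methyl Group from Compound 2

This account rests on a few compounds, and the source may have more. Where it says the series, first, only, none or still open, it means among the compounds named here.

In an in vivo ADME assay on the whole organism (strain Sprague-Dawley) for pharmacokinetics, with Rattus norvegicus as the target (a higher number here means that a larger share of the oral dose reaches the circulation, a lower number that a smaller share of the oral dose reaches the circulation), compound 1 (`CN(C)C1CCc2cc(N3CC[C@H](NS(=O)(=O)/C=C/c4ccc(Cl)s4)C3=O)ccc21`) gives 57% and compound 2 (`CN1CCCC1c1ccc(N2CC[C@H](NS(=O)(=O)/C=C/c3ccc(Cl)s3)C2=O)c(F)c1`) gives 41% as the lower of the two numbers, a gap beyond the usual scatter. Compound 3 (`O=C1[C@@H](NS(=O)(=O)/C=C/c2ccc(Cl)s2)CCN1c1ccc(C2CCCN2)cc1F`) departs from compound 2 at one place (hydrogen in place of methyl on an amine nitrogen in a ring): hydrogen in place of methyl on an amine nitrogen in a ring. Among the compounds with values here, no measured pair of compounds shows this change, so the expectation remains loose. The expected change (a number 7 percentage points lower from compound 2 to compound 3 (within the scatter)) is a modest fall in this assay that may stay within the scatter. For compound 3 the estimate is 34% with an expected range from 15% to 52% as the likely span.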

Compound 3, oral bioavailability: 52%
Beside the measured number, compound 3's estimate is 18 percentage points below it, and the stated range covers the measured number.
By their numbers in this assay, from the lowest: compound 2; then compounds 3 and 1 (each within the scatter of the next).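

In this assay the change from 1-methylpyrrolidin-2-yl to pyrrolidin-2-yl gives a number 11 percentage points higher from compound 2 to compound 3 (beyond the scatter), the first step read at a single place, since compound 1 and compound 2 differ in more than one. On this amine nitrogen in a ring, then, hydrogen in place of methyl does not lower the oral bioavailability of this pair but raises it. Nothing measured here accounts for the rise.

On these data alone, what an ethyl or an acetyl group on this nitrogen would do remains open. So does whether the same step would hold on another core.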